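This account rests on a few compounds, and the source may have more. Where it says the series, first, only, none or still open, it means among the compounds named here.

The measured compounds:

Compound 1 `Cn1cncc1CN1CC(N(CC2CCN(C(=O)c3ccc(Cl)cc3)CC2)S(=O)(=O)c2ccccn2)Cc2cc(C#N)ccc21`: 0.5 10^-6 cm/s
Compound 2 `CCC(=O)N1CCC(CN(C2Cc3cc(C#N)ccc3N(Cc3cncn3C)C2)S(=O)(=O)c2ccccn2)CC1`: 0.5 10^-6 cm/s
Compound 3 `C=C(C)C(=O)N1CCC(CN(C2Cc3cc(C#N)ccc3N(Cc3cncn3C)C2)S(=O)(=O)c2ccccn2)CC1`: 0.5 10^-6 cm/s

In an ADME assay on Caco-2 cells (Homo sapiens) for permeability, in the apical to basolateral direction (on this read-out lower numbers stand for lower permeability and higher numbers for higher permeability), compound 2 stands level with compound 1 and compound 3 at the digits reported; its nearest neighbour is compound 1 and its furthest is compound 3, and neither gap reaches beyond the scatter. All three compounds share one core and differ only in the group on the carbonyl carbon of the piperidine amide.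

Compound 4 `Cn1cncc1CN1CC(N(CC2CCN(C(=O)OC(C)(C)C)CC2)S(=O)(=O)c2ccccn2)Cc2cc(C#N)ccc21` is not yet measured in this assay. It differs from compound 2 as follows: tert-butoxy in place of ethyl on a carbonyl carbon.

Among the compounds with values here, three measured steps bear on this change, all of them exchanges at the same carbonyl carbon: no change at the digits printed from compound 1 to compound 2 (within the scatter); no change at the digits printed from compound 1 to compound 3 (within the scatter); no change at the digits printed from compound 2 to compound 3 (within the scatter). None of them moved the read-out beyond the scatter, whether the group was 4-chlorophenyl, ethyl or 1-methylethenyl. As far as these compounds go, a tert-butoxy at this position is untested here, so the expectation rests on those three steps alone.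

The step of no change at the digits printed from compound 2 to compound 4 (within the scatter) is therefore expected to stay within the scatter. Compound 4 is estimated at 0.5 10^-6 cm/s, with a range from 0.25 10^-6 cm/s to 1 10^-6 cm/s.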

Compound 4, apparent permeability: 15.5 10^-6 cm/s
For compound 4 the middle estimate is 31-fold (1.49 log units) below the measured one, outside the stated range (above it).
By their numbers in this assay, from the lowest: compounds 1, 2 and 3 (each within the scatter of the next); then compound 4.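

In this assay this carbonyl carbon, which had shown no response across 4-chlorophenyl, ethyl and 1-methylethenyl, proves sensitive to what it carries: tert-butoxy gives a 31-fold higher number from compound 2 to compound 4 (1.49 log units; beyond the scatter) and, against the other two groups, a 31-fold higher number from compound 3 to compound 4 (1.49 log units; beyond the scatter) and a 31-fold higher number from compound 1 to compound 4 (1.49 log units; beyond the scatter) as well. The rise therefore follows this one group and not the size of the earlier exchanges, and compound 4 is the only one of the four with an oxygen on this carbonyl carbon, turning the propanoyl of compound 2 into tert-butoxycarbonyl. Nothing given here offers an explanation for the jump.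

The compounds shown do not separate the oxygen from the branched tert-butyl part, which a methoxy or a plain tert-butyl on the same carbonyl carbon would do. As far as these compounds go, whether a dimethylamino group there would behave like tert-butoxy also remains open.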